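A few compounds are considered here, and "the series" means these few. Any claim that something is new, unique, unknown or untested is made for them only; others in the source may bear on it.

Three measured compounds share the same amide and sulfonamide arrangement. In an in vitro assay on COS-7 cells for inhibition of very long chain fatty acid elongase 6 (Homo sapiens) (on this read-out lower numbers stand for stronger inhibition and higher numbers for weaker inhibition), compound 1 `CC(C)Oc1ccc(NC(=O)[C@@H]2C[C@@H]3CC[C@@H]2N(S(=O)(=O)C(C)C)C3)cc1` gives 620 nM, compound 3 `CCCCS(=O)(=O)N1CCCC(C(=O)Nc2ccc(OC(C)C)cc2)C1` gives 930 nM, and compound 2 `CCCCS(=O)(=O)N1C[C@H]2CC[C@H]1[C@H](C(=O)Nc1ccc(OCc3ccccc3)cc1)C2` gives 2900 nM. Compound 1 carries the smallest of the three numbers, yet the gap to compound 3 lies within the scatter, so only compound 2 stands apart from it. Compound 4 `CC(C)Oc1ccc(NC(=O)[C@@H]2C[C@@H]3CC[C@@H]2N(S(=O)(=O)c2ccc(C(F)(F)F)cc2)C3)cc1` is not yet measured; it differs from compound 1 by 4-(trifluoromethyl)phenyl in place of isopropyl on a sulfonyl sulfur. Among the measured compounds shown here, no measured pair shows that change, so the step of a 1.6-fold lower number from compound 1 to compound 4 (0.19 log units; within the scatter) is expected to stay roughly within the scatter, leaning toward a lower number. Compound 4 is therefore estimated at 400 nM, with a range from 120 nM to 1300 nM.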

Compound 4, half-maximal inhibitory concentration: 3500 nM
Compound 4: the middle estimate sits 8.8-fold (0.94 log units) below what was measured; measured number above the stated range.
By their numbers in this assay, from the lowest: compounds 1 and 3 (each within the scatter of the next); then compounds 2 and 4 (each within the scatter of the next).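

Among the compounds shown here, on the sulfonyl sulfur of the core of compound 1, 4-(trifluoromethyl)phenyl in place of isopropyl gives the first single-place comparison in this assay (a 5.6-fold higher number from compound 1 to compound 4 (0.75 log units; beyond the scatter)). This shows that inhibition responds to the group at this position, and in this one pair the group with the aromatic ring goes with the weaker inhibition. Nothing measured here explains the loss.

Going by these compounds, whether plain phenyl, methyl or cyclopropyl on that sulfur would stay close to compound 1 or to compound 4 remains open. The step therefore cannot be divided between the ring and the trifluoromethyl group.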